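Propyl to pentyl on the phenoxy side of the amide series

The source may hold more compounds than are shown below. What is called first, only, known or untested is meant among the compounds shown, and "the series" means these compounds.

Compound 2 `CCCc1ccc(OCC(=O)Nc2cccc(C(=O)OC)c2)cc1` carries a propyl chain on the aromatic ring of its phenoxy part. In an assay on isolated protein for inhibition of malate dehydrogenase, mitochondrial (Homo sapiens), with a stated time of 30 min (a lower number here means a stronger inhibitor, a higher number a weaker inhibitor), compound 2 gives only a limit of the assay, > 40000 nM, so its standing on the numbers shown is a limit and not a position. Compound 1 `COC(=O)c1cccc(NC(=O)COc2ccc(C)cc2)c1` is the matching analogue with hydrogen in place of that propyl. In this assay compound 1 likewise returns only a limit, > 40000 nM. Within the data shown here, the single step joining the two measured compounds, a step that the two limits leave unreadable from compound 1 to compound 2, has no readable size because the limit of > 40000 nM in this assay, at which 2 of the 2 values shown sit, holds both values.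

Compound 3 `CCCCCc1ccc(OCC(=O)Nc2cccc(C(=O)OC)c2)cc1` differs from compound 2 by ethyl in place of hydrogen on a saturated chain carbon, three bonds along the chain from an aromatic carbon. Among the measured compounds shown here, only one measured step is of the same kind, a chain lengthening at this position, and it is unreadable, so no direction or size can be taken from it; a shift within the scatter or none at all is the working expectation. Compound 3 is therefore expected to remain at the limit, with an estimate of 60000 nM in this assay and a range from 20000 nM to 200000 nM. The expected step that the limit leaves unreadable from compound 2 to compound 3 is thus estimated as not beyond the scatter.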

Compound 3, half-maximal inhibitory concentration: > 40000 nM
Compound 3: only a limit was reported; the forecaster's own chance of this, stated with the estimate: 85%; the middle value lies beyond the limit too.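

No step can be read among compound 1, compound 2 and compound 3, since each result is only a limit and all three sit at the same one: the limit of > 40000 nM in this assay, at which 3 of the 3 values shown sit.

The compounds shown leave open whether lengthening this chain changes inhibition at all in this assay, and how far any of the three lies from that limit.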